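Cytotoxicity Outlook When an Oxolane Replaces a Fused Carbocycle

The source may hold more compounds than are shown below. What is called first, only, known or untested is meant among the compounds shown, and "the series" means these compounds.

Compound 2 `OC[C@@]12C[C@@H]1[C@@H](n1cnc3c(NC(C4CCC4)C4CCC4)nc(Cl)nc31)[C@H](O)[C@@H]2O` carries, on an aromatic nitrogen of the shared core, a group of 10 heavy atoms (7 carbon, 3 oxygen; one three-membered non-aromatic ring of carbon only, one five-membered non-aromatic ring of carbon only). Among the compounds with values here, in an ADME assay on Vero 76 cells (Chlorocebus sabaeus) for cytotoxicity, read by microscopy (a higher number here means that more compound is tolerated, a lower number that less compound is tolerated), compound 2 gives 50000 nM, the highest of the two numbers measured so far. Compound 1 `O[C@@H]1[C@H](O)[C@@H]2C[C@@H]2[C@H]1n1cnc2c(NC(C3CCC3)C3CCC3)nc(Cl)nc21` differs from it only in that same group, and in this assay compound 1 gives 16000 nM. The step of a 3.1-fold higher number from compound 1 to compound 2 (0.49 log units; beyond the scatter) shows that reshaping this group can shift the read-out, though not dramatically. Compound 3 `OC[C@H]1O[C@@H](n2cnc3c(NC(C4CCC4)C4CCC4)nc(Cl)nc32)[C@H](O)[C@@H]1O` has not been measured; it differs from compound 2 as follows: a group of 9 heavy atoms (5 carbon, 4 oxygen; one five-membered non-aromatic ring with 1 hetero atom) in place of a group of 10 heavy atoms (7 carbon, 3 oxygen; one three-membered non-aromatic ring of carbon only, one five-membered non-aromatic ring of carbon only), on an aromatic nitrogen. Within the data shown here, only the step from compound 1 to compound 2 bears on this change, and it altered the same group in a different way, so it guides direction only weakly. Because a 3.1-fold higher number from compound 1 to compound 2 (0.49 log units; beyond the scatter) was modest, a shift of similar size either way, or none beyond the scatter, is plausible. The step of no change at the digits printed from compound 2 to compound 3 (within the scatter) is therefore what is expected. Compound 3 is estimated at 50000 nM, within 15000 nM to 160000 nM.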

Compound 3, half-maximal cytotoxic concentration: 32000 nM
For compound 3 the middle estimate is 1.6-fold (0.19 log units) above the measured one, and the stated range covers the measured number.
By their numbers in this assay, from the lowest: compounds 1, 3 and 2 (each within the scatter of the next, the first and the last beyond it).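

Putting 3,4-dihydroxy-5-(hydroxymethyl)oxolan-2-yl on this aromatic nitrogen, where compound 2 carries its group with the three-membered and five-membered carbon rings, gives a number in this assay that cannot be told apart from that of compound 2 (a 1.6-fold lower number from compound 2 to compound 3 (0.19 log units; within the scatter)). Compound 3 also lies within the scatter of compound 1 (a 2.0-fold higher number from compound 1 to compound 3 (0.30 log units; within the scatter)), even though the two carbon-ring compounds are separated by more than the scatter (a 3.1-fold higher number from compound 1 to compound 2 (0.49 log units; beyond the scatter)). So the oxolane ring, with its ring oxygen and without a three-membered ring, gives a number in the same range as both carbon-ring compounds, and these data cannot place compound 3 closer to either one.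

No measured evidence is available to explain why the three numbers fall where they do. The compounds shown also leave open whether a group carrying an amine or a carboxylic acid in place of the hydroxymethyl would move the number beyond the scatter, and whether the oxolane would give a similar result on a different core.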